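Side-Chain Extension on the Amino Ester of Compound 3

The source may hold more compounds than are shown below. What is called first, only, known or untested is meant among the compounds shown, and "the series" means these compounds.

Compound 1 `O=C(CN(c1ncnc2c1ncn2C1CCCCO1)C1CC1)N[C@@H](CCC(=O)OCc1ccccc1)C(=O)OCc1ccccc1` gives 32.6% in a functional assay on the whole organism (Tail, strain ICR) with Mus musculus as the target, in the tail flick test, with a stated time of 30 min, at a dose of 25 umol/kg by the oral route; a higher number here means a stronger effect of the compound at the dose given, a lower number a weaker effect.
Compound 2 `C[C@@H](O)[C@H](NC(=O)CN(c1ncnc2c1ncn2C1CCCCO1)C1CC1)C(=O)OCc1ccccc1` gives 23.6% in this assay.
Compound 3 `C[C@H](NC(=O)CN(c1ncnc2c1ncn2C1CCCCO1)C1CC1)C(=O)OCc1ccccc1` gives 55.9% in this assay.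

Among these three, compound 3 stands highest; compound 1 is nearest and compound 2 furthest, and both gaps lie beyond the scatter. Compound 4 `CC(C)(C)OC(=O)NCCCC[C@H](NC(=O)CN(c1ncnc2c1ncn2C1CCCCO1)C1CC1)C(=O)OCc1ccccc1` has not yet been measured. It differs from compound 3 in one place: 3-((tert-butoxycarbonyl)amino)propyl in place of hydrogen on a saturated chain carbon, two bonds along the chain from an amide-type nitrogen and a carbonyl carbon. The step that bears most directly on this change is a number 23.3 percentage points higher from compound 1 to compound 3 (beyond the scatter), which concerns the same chain carbon and shows that a hydrogen there goes with the higher number and a larger substituent with the lower one. The step of a number 32.3 percentage points higher from compound 2 to compound 3 (beyond the scatter) points the same way for a neighbouring position: the smaller group accompanies the higher number. Compound 4 carries a large substituent where compound 3 has hydrogen, so a drop in this assay, beyond the scatter and of modest to large size, is expected; the estimated step is a number 22.9 percentage points lower from compound 3 to compound 4 (beyond the scatter). Compound 4 is therefore expected to give about 33%, with a likely range from 15% to 50%.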

Compound 4, a percentage reported as activity, at one dose (the size of the read-out at that dose, not a potency): 18.3%
Estimate against measurement, compound 4: 14.7 percentage points above, within the range that was stated.
By their numbers in this assay, from the lowest: compounds 4, 2 and 1 (each within the scatter of the next, the first and the last beyond it); then compound 3.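

In this assay, placing 3-((tert-butoxycarbonyl)amino)propyl on this saturated chain carbon gives a number 37.6 percentage points lower from compound 3 to compound 4 (beyond the scatter) as a large step. The lower number seen with the (benzyloxycarbonyl)methyl group at this carbon is therefore not confined to that group, since a second substituent, one with no ring, also goes with a lower number than hydrogen gives. The substituents do not all fall level, though: the step of a number 14.3 percentage points lower from compound 1 to compound 4 (beyond the scatter) is modest, while the step of a number 5.3 percentage points lower from compound 2 to compound 4 (within the scatter) leaves compound 2 and compound 4 not distinguishable in this assay.

Nothing available explains the effect of these substituents. Still open, on these data alone, is whether a free amine at the end of the chain, a carboxylic acid there, or a plain butyl chain would keep the number of compound 3.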